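Adding trifluoromethyl to compound 2

This account rests on a few compounds, and the source may have more. Where it says the series, first, only, none or still open, it means among the compounds named here.

In a functional assay on Gurav cells (Homo sapiens) for inhibition, read by sulforhodamine B assay (a lower number here means a stronger inhibitor of growth, a higher number a weaker inhibitor of growth), compound 1 (`FC(F)(F)c1ccc(-c2ccc(-c3ccc(-c4nc5ccccc5[nH]4)cc3)cc2)cc1`) gives 39100 nM. Compound 2 (`Cc1ccc2[nH]c(-c3ccc(-c4ccc(-c5ccccc5)cc4)cc3)nc2c1`) gives 3310 nM, the lower of the two numbers, by a gap beyond the scatter. Compound 3 (`Cc1ccc2[nH]c(-c3ccc(-c4ccc(-c5ccc(C(F)(F)F)cc5)cc4)cc3)nc2c1`) has trifluoromethyl in place of hydrogen on an aromatic carbon of compound 2, para to a large group: trifluoromethyl in place of hydrogen on an aromatic carbon. Within the data shown here, no measured step isolates this change. Among the measured compounds shown here, compound 1, the only measured compound with a 4-(trifluoromethyl)phenyl group, gives 39100 nM, so a moderately higher number, beyond the scatter, is expected in this assay. The estimated step is a 2.7-fold higher number from compound 2 to compound 3 (0.43 log units; beyond the scatter). Compound 3 is expected at 9000 nM, within an estimated range of 3000 nM to 30000 nM.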

Compound 3, concentration for 50% growth inhibition: 12000 nM
Beside the measured number, compound 3's estimate is 1.3-fold (0.12 log units) below it; the range from low to high includes it.
By their numbers in this assay, from the lowest: compound 2; then compound 3; then compound 1.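

In this assay the change now stands as a direct single-place comparison: trifluoromethyl in place of hydrogen on an aromatic carbon, para to a large group, gives a 3.6-fold higher number from compound 2 to compound 3 (0.56 log units; beyond the scatter). The methyl change on the shared core, with trifluoromethyl held in place, gives a 3.3-fold lower number from compound 1 to compound 3 (0.51 log units; beyond the scatter), so growth inhibition is weaker with trifluoromethyl and stronger with methyl. Nothing available explains either step.

Open, on these data alone, is whether an amine, a carboxylic acid or a methoxy group at the same carbon would give a lower number. Also open, as far as these compounds go, is whether the methyl step holds without trifluoromethyl.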